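This account rests on a few compounds, and the source may have more. Where it says the series, first, only, none or still open, it means among the compounds named here.

Measured compounds:
compound 1 `O=C(OCc1ccccc1)N1CCN(C(=S)SCc2cn(Cc3ccc(F)cc3)nn2)CC1` – 32000 nM
compound 2 `O=C(OCc1ccccc1)N1CCN(C(=S)SCc2cn(Cc3ccccc3F)nn2)CC1` – 27000 nM

In a functional assay on ECa-109 cells (Homo sapiens) for inhibition, read by MTT assay, with a stated time of 72 h (a higher number here means a weaker inhibitor, a lower number a stronger inhibitor), compound 1 gives 32000 nM, and in this assay compound 2 gives 27000 nM. Compound 2 stands beside compound 1: the step of a 1.2-fold lower number from compound 1 to compound 2 (0.07 log units; within the scatter) lies within the scatter, so the two compounds cannot be told apart on these numbers, and both are weak inhibitors.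

Compound 3 `Fc1ccccc1Cn1cc(CSC(=S)N2CCNCC2)nn1` has not yet been measured. It differs from compound 2 in one place: hydrogen in place of benzyloxycarbonyl on an amine nitrogen in a ring. Among the compounds with values here, the only measured step, a 1.2-fold lower number from compound 1 to compound 2 (0.07 log units; within the scatter), concerns the fluorophenyl ring and says nothing about a change at the amine nitrogen of the six-membered ring, so no measured step bears on this change. With no guide to direction, the expected step for compound 3 is a 1.3-fold higher number from compound 2 to compound 3 (0.11 log units; within the scatter), not beyond the scatter. Compound 3 is therefore estimated at 35000 nM, with a broad range from 10000 nM to 120000 nM.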

Compound 3, half-maximal inhibitory concentration: > 128000 nM
Compound 3 gave a limit, no number (the forecaster's own chance of this, stated with the estimate: 15%); at least 3.6-fold (0.56 log units) between middle value and limit.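

Compound 1 and compound 2 differ only in the fluorophenyl ring, so they said nothing about the amine nitrogen of the six-membered ring. In this assay, hydrogen in place of benzyloxycarbonyl on that nitrogen gives an at least 4.7-fold higher number from compound 2 to compound 3 (0.67 log units; beyond the scatter), so this change, unlike the fluorine step, has an effect beyond the scatter, and the already weak inhibition of compound 2 depends on what sits on this nitrogen. The value of compound 3, > 128000 nM, is a limit of the assay and not a number: the limit of > 128000 nM in this assay, at which 1 of the 3 values shown sits.

The compounds shown leave open which part of the benzyloxycarbonyl group matters. A plain benzyl group or a small acetyl group on the same nitrogen would help separate the role of the aromatic ring from that of the carbonyl.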